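This account rests on a few compounds, and the source may have more. Where it says the series, first, only, none or still open, it means among the compounds named here.

Measured compounds:
- compound 1, `Nc1ccccc1NC(=O)c1ccc(CSc2ccc(Br)cc2)cc1`: 33.2%
- compound 2, `Nc1ccccc1NC(=O)/C=C/c1ccc(CSc2ccc(F)cc2)cc1`: 51.2%
- compound 3, `Cc1cc(C)cc(SCc2ccc(/C=C/C(=O)Nc3ccccc3N)cc2)c1`: 46.1%

All three numbers come from a functional assay on A549 cells (Homo sapiens) for inhibition, read by CCK-8 assay, with a stated time of 72 h, tested at 2 uM; on this read-out lower numbers stand for less inhibition of growth and higher numbers for more inhibition of growth at the one concentration tested. Among them compound 1 stands lowest: compound 3 lies nearest, and compound 2 lies furthest, both beyond the scatter of repeated runs.

Compound 4, `Cc1ccc(SCc2ccc(C(=O)Nc3ccccc3N)cc2)cc1`, has not yet been measured in this assay. Starting from compound 1, the change is methyl in place of bromo on an aromatic carbon.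

Within the data shown here, only one measured step touches the same part of the molecule, the ring on the sulfur: a number 5.1 percentage points lower from compound 2 to compound 3 (within the scatter). That step swaps one substituted ring for another on the sulfur, in a pair built on a longer linker than compound 1 and compound 4 share, and it stays within the scatter. Among the measured compounds shown here, no measured pair exchanges bromo for methyl, so the step from compound 1 to compound 4 has no direct precedent. For the measured compounds named here, the one related step gives no reason to expect a move beyond the scatter in this assay, in either direction, so compound 4 is expected to stay close to compound 1, with an estimated step of a number 1.8 percentage points higher from compound 1 to compound 4 (within the scatter). For compound 4 the estimate is 35%, expected to fall between 22% and 48%.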

Compound 4, percent growth inhibition at one concentration: 40.5%
Compound 4: the middle estimate sits 5.5 percentage points below what was measured; measured number inside the range.
By their numbers in this assay, from the lowest: compounds 1, 4, 3 and 2 (each within the scatter of the next, the first and the last beyond it).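

In this assay, methyl in place of bromo on the ring on the sulfur gives a number 7.3 percentage points higher from compound 1 to compound 4 (within the scatter), and the 4-bromophenyl and 4-methylphenyl forms of this core cannot be told apart at the one concentration tested. Among these compounds, this is the first measured change to that ring on the shorter linker; the earlier step, a number 5.1 percentage points lower from compound 2 to compound 3 (within the scatter), comes from the longer linker and also stays within the scatter. The data at hand offer no explanation for the size of the new step.

Still open, going by these compounds, is whether a different kind of group at this place, such as an amine or a carboxylic acid, would move growth inhibition beyond the scatter. Also open, on these data alone, is whether methyl in place of bromo would give a similar step on the longer linker.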